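The source may report more compounds than this note shows. Statements on the series, on what has been measured and on what is new or still open speak of the compounds shown alone.

Of the compounds shown here, three of one shared core have been measured, and a fourth waits. Compound 1 `CC(=O)c1ccc2c(c1)nc(-c1ccc(Cl)cc1)n2C1CCCCC1` carries an acetyl group on the core and a chloro group on the pendant ring. In an ADME assay on BHK-21 cells (Mesocricetus auratus) for cytotoxicity, read by MTT assay (a higher number here means that more compound is tolerated, a lower number that less compound is tolerated), compound 1 gives > 100000 nM, which is a limit of the assay rather than a number. Compound 2 `CC(=O)c1ccc2c(c1)nc(-c1ccc(C(F)(F)F)cc1)n2C1CCCCC1` differs from compound 1 by trifluoromethyl in place of chloro on an aromatic carbon and in this assay compound 2 gives 33000 nM. That change made an at least 3.0-fold lower number from compound 1 to compound 2 (0.48 log units; beyond the scatter). Compound 3 `C/C(=N\NC(N)=S)c1ccc2c(c1)nc(-c1ccc(Cl)cc1)n2C1CCCCC1` differs from compound 1 by a group of 7 heavy atoms (3 carbon, 3 nitrogen, 1 sulfur; no ring) in place of a group of 3 heavy atoms (2 carbon, 1 oxygen; no ring), on an aromatic carbon; in this assay compound 3 gives > 100000 nM, again a limit of the assay and not a number. The step is a step that the two limits leave unreadable from compound 1 to compound 3, since the limit of > 100000 nM in this assay, at which 2 of the 3 values shown sit, is where two of the three values sit.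

Compound 4 `C/C(=N\NC(N)=S)c1ccc2c(c1)nc(-c1ccc(C(F)(F)F)cc1)n2C1CCCCC1` is not yet measured. It differs from compound 3 by trifluoromethyl in place of chloro on an aromatic carbon, and the two cores differ by the same change already told for compound 3 against compound 1. The place around the change matches word for word what holds for compound 2 against compound 1, so this is the same change, seen a second time. Beside the measured step of an at least 3.0-fold lower number from compound 1 to compound 2 (0.48 log units; beyond the scatter), the expected step is an at least 2.0-fold lower number from compound 3 to compound 4 (0.30 log units; that floor lies within the scatter), resting on compound 2 and its value 33000 nM after the same swap. Compound 4 is therefore estimated at 50000 nM, expected between 15000 nM and 150000 nM.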

Compound 4, half-maximal cytotoxic concentration: > 100000 nM
Compound 4: a limit, no number (the forecaster's own chance of this, stated with the estimate: 40%); at least 2.0-fold (0.30 log units) between middle value and limit.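

In this assay compound 4 gives > 100000 nM, which is a limit of the assay and not a number. The step for trifluoromethyl in place of chloro on the second core cannot be read, and the same holds for every other step that joins two limits, because compound 3 and compound 4 both sit at that limit: the limit of > 100000 nM in this assay, at which 3 of the 4 values shown sit.

Among these compounds, on the first core the same swap gave an at least 3.0-fold lower number from compound 1 to compound 2 (0.48 log units; beyond the scatter), and that result is neither repeated nor contradicted on the second core; the one new step that can be read is an at least 3.0-fold higher number from compound 2 to compound 4 (0.48 log units; beyond the scatter), which ties the group of 7 heavy atoms, in place of the group of 3 heavy atoms, to a higher number when trifluoromethyl is present.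

The compounds shown leave open what actual numbers compound 1, compound 3 and compound 4 would give, so the size of the swap on the second core stays unknown. They also leave open how an amine or a carboxylic acid in place of chloro or trifluoromethyl would fare in this assay.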